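Compound 4 against compound 2: a hydroxy exchange

A few compounds are considered here, and "the series" means these few. Any claim that something is new, unique, unknown or untested is made for them only; others in the source may bear on it.

- compound 1 `CC(=O)N1N=C(c2ccc3ccccc3c2)OC1c1cccc(Br)c1`: 2.36 ug/mL
- compound 2 `CC(=O)N1N=C(c2ccc3ccccc3c2)OC1c1ccc(Cl)cc1`: 2.48 ug/mL
- compound 3 `CC(=O)N1N=C(c2ccc3ccccc3c2)OC1c1ccc(F)cc1`: 4.65 ug/mL

These values come from a functional assay on B16-F10 cells (Mus musculus) for antiproliferative activity, read by MTT assay, with a stated time of 48 h; on this read-out lower numbers stand for stronger inhibition and higher numbers for weaker inhibition. Compound 2 stands within the scatter of the other two: a 1.1-fold higher number from compound 1 to compound 2 (0.02 log units; within the scatter) and a 1.9-fold higher number from compound 2 to compound 3 (0.27 log units; within the scatter). The open case is compound 4 `CC(=O)N1N=C(c2ccc3ccccc3c2)OC1c1ccccc1O`, with 2-hydroxyphenyl in place of 4-chlorophenyl on a saturated ring carbon. The nearest evidence is a 1.9-fold higher number from compound 2 to compound 3 (0.27 log units; within the scatter), and a 2.0-fold higher number from compound 1 to compound 3 (0.29 log units; within the scatter) also bears on it. Within the data shown here, both exchange only halogen-bearing phenyl groups, so no measured step tests a hydroxy group. A small step towards a higher number, not beyond the scatter, is therefore expected. The expected step is a 1.4-fold higher number from compound 2 to compound 4 (0.15 log units; within the scatter). For compound 4 the estimated value in this assay is 3.5 ug/mL, with an expected range of 1.2 ug/mL to 10 ug/mL.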

Compound 4, half-maximal inhibitory concentration: 2.58 ug/mL
Estimate against measurement, compound 4: 1.4-fold (0.13 log units) above, within the range that was stated.
By their numbers in this assay, from the lowest: compounds 1, 2, 4 and 3 (each within the scatter of the next).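

In this assay, among these compounds, 2-hydroxyphenyl is the first group without a halogen at this saturated ring carbon, and it lies within the scatter of all three halogen-bearing compounds (a 1.0-fold higher number from compound 2 to compound 4 (0.02 log units; within the scatter); a 1.8-fold lower number from compound 3 to compound 4 (0.26 log units; within the scatter); a 1.1-fold higher number from compound 1 to compound 4 (0.04 log units; within the scatter)). The series therefore shows no readable change at this position when a halogen-bearing phenyl gives way to a phenyl with a hydroxy group, even with the hydrogen-bond donor and acceptor counted for 2-hydroxyphenyl. No other data bear on this result.

From the compounds shown here alone, whether an amine or a carboxylic acid on this phenyl ring would give a step beyond the scatter remains open. Also open, going by these compounds, is how a hydroxy group elsewhere on the ring would compare.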